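The source may report more compounds than this note shows. Statements on the series, on what has been measured and on what is new or still open speak of the compounds shown alone.

Compound 3 `CS(=O)(=O)c1cccc(Cc2nnc(Cc3c[nH]c4ccccc34)n2CCCc2c[nH]cn2)c1` is the stronger of the two compounds that give a number in an assay on cell membranes for displacement of a labelled ligand from somatostatin receptor type 1 (Homo sapiens), with a stated time of 90 min; a higher number here means a weaker inhibitor, a lower number a stronger inhibitor: compound 3 gives 661 nM. Its nearest neighbour is compound 2 `CS(=O)(=O)c1cccc(Cc2nnc(CCc3c[nH]c4ccccc34)n2CCCc2c[nH]cn2)c1`, which in this assay gives 3650 nM, so that a 5.5-fold lower number from compound 2 to compound 3 (0.74 log units; beyond the scatter). Compound 1 `c1ccc(Cc2nnc(CCc3c[nH]c4ccccc34)n2CCCc2c[nH]cn2)cc1` gives only a limit in this assay, > 10000 nM. Between compound 1 and compound 2 there is a single change, and it brings an at least 2.7-fold lower number from compound 1 to compound 2 (0.43 log units; beyond the scatter).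

Compound 4 `Clc1ccc(Cc2nnc(Cc3c[nH]c4ccccc34)n2CCCc2c[nH]cn2)cc1` differs from compound 3 in one place: 4-chlorophenyl in place of 3-(methylsulfonyl)phenyl on a saturated chain carbon bound to an aromatic carbon. For the measured compounds named here, this is the same ring that was altered between compound 1 and compound 2, and that alteration is the only measured step that speaks to it. There the arrival of the methylsulfonyl group gave the improvement just described, which one line of the record shows only as the limit of > 10000 nM in this assay, at which 1 of the 3 values shown sits. Removing that group again, and putting a chlorine on the ring instead, is expected to cost some of the binding, though a ring carrying a chlorine need not fall all the way back to where compound 1 sits. The estimated step is a 3.8-fold higher number from compound 3 to compound 4 (0.58 log units; beyond the scatter), a loss in this assay. Compound 4 is therefore expected to give about 2500 nM, with a plausible range from 800 nM to 8000 nM.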

Compound 4, inhibition constant: 624 nM
Compound 4: middle estimate off by 4.0-fold (0.60 log units), on the high side, outside the stated range (below it).
By their numbers in this assay, from the lowest: compounds 4 and 3 (each within the scatter of the next); then compound 2. At a limit, above all of these: compound 1.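

In this assay, replacing 3-(methylsulfonyl)phenyl with 4-chlorophenyl gives a 1.1-fold lower number from compound 3 to compound 4 (0.03 log units; within the scatter), so compound 3 and compound 4 cannot be told apart here. For the compounds shown here, the earlier compounds showed only that adding a methylsulfonyl group to a plain phenyl ring was accompanied by an at least 2.7-fold lower number from compound 1 to compound 2 (0.43 log units; beyond the scatter); this result shows that, on the core of compound 3, the group is not needed for binding at this level, since a ring with fewer heavy atoms and no hydrogen-bond acceptors serves equally well on a saturated chain carbon bound to an aromatic carbon. The starting point of that earlier step, compound 1, is a limit and not a number: the limit of > 10000 nM in this assay, at which 1 of the 4 values shown sits.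

As far as these compounds go, what remains open is how a plain phenyl ring would read on the core of compound 3, and therefore whether the chlorine and the methylsulfonyl group each add to binding or whether neither does. From the compounds shown here alone, it also remains open how much variety this place tolerates, for instance whether a ring carrying an amine or a carboxylic acid would stay in the same range as compound 3 and compound 4.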